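The source may hold more compounds than are shown below. What is called first, only, known or untested is meant among the compounds shown, and "the series" means these compounds.

Three compounds built on a shared core, differing in the group on the sulfonyl sulfur, have been tested in an ADME assay on IMR-90 cells (Homo sapiens) for cytotoxicity, read by CellTiter-Blue, with a stated time of 46 h; on this read-out higher numbers stand for an effect only at larger amounts of compound and lower numbers for an effect already at smaller amounts. Compound 1 `CC1(C)CCN(S(=O)(=O)c2ccc(NC(=O)c3ccc([N+](=O)[O-])o3)cc2)CC1` carries 4,4-dimethylpiperidin-1-yl, and in this assay compound 1 gives > 25000 nM, which is a limit of the assay and not a number. Compound 2 `CC(C)(C)C1CCN(S(=O)(=O)c2ccc(NC(=O)c3ccc([N+](=O)[O-])o3)cc2)CC1` carries 4-(tert-butyl)piperidin-1-yl, and in this assay compound 2 likewise gives the limit > 25000 nM. Compound 3 `O=C(Nc1ccc(S(=O)(=O)N2CCC(O)CC2)cc1)c1ccc([N+](=O)[O-])o1` carries 4-hydroxypiperidin-1-yl, and in this assay compound 3 again stops at the limit > 25000 nM. Compound 3 thus stands exactly where all three values stand, at the limit of > 25000 nM in this assay, at which 3 of the 3 values shown sit. The steps a step that the two limits leave unreadable from compound 1 to compound 2, a step that the two limits leave unreadable from compound 1 to compound 3 and a step that the two limits leave unreadable from compound 2 to compound 3 are all unreadable in size, each having both ends at that limit.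

The next compound, compound 4 `O=C(Nc1ccc(S(=O)(=O)N2CCC(Cl)CC2)cc1)c1ccc([N+](=O)[O-])o1`, differs from compound 3 by chloro in place of hydroxy on a saturated ring carbon. The closest comparison is a step that the two limits leave unreadable from compound 2 to compound 3, where a group on a saturated ring carbon was exchanged without either value leaving the limit. Compound 4 is therefore expected to remain at the limit as well, with an estimated step of a number no higher from compound 3 to compound 4 (the limit leaves the size open) that cannot be separated from the scatter. The estimate for compound 4 in this assay is 25000 nM, ranging from 8000 nM to 80000 nM.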

Compound 4, half-maximal effective concentration: > 25000 nM
Compound 4 gave a limit, no number; the forecaster's own chance of this, stated with the estimate: 80%; the middle value sits exactly at the limit.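

Compound 4 gives a limit, not a number, in this assay, so no step between compound 4 and compound 1, compound 2 or compound 3 can be read: the limit of > 25000 nM in this assay, at which 4 of the 4 values shown sit.

The compounds shown leave open whether the groups on the sulfonyl sulfur differ at all in this assay, and at what concentration any of the four would reach a half-maximal effect.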